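This account rests on a few compounds, and the source may have more. Where it says the series, first, only, none or still open, it means among the compounds named here.

Going by the values given here, compound 3 `COc1cccc(CCC(=O)Nc2nc3ccccc3c(=O)s2)c1` gives 1370 nM in an assay on CHO cells for displacement of a labelled ligand from adenosine receptor A1 (Homo sapiens), read by scintillation counting, with a stated time of 90 min (on this read-out lower numbers stand for stronger inhibition and higher numbers for weaker inhibition), the highest of the three numbers known so far. Compound 2 `O=C(CCc1ccccc1)Nc1nc2ccccc2c(=O)s1` gives 1050 nM in this assay, and compound 1 `COc1cccc(CCCC(=O)Nc2nc3ccccc3c(=O)s2)c1` gives 214 nM. Among the compounds with values here, the only single-point step among the measured compounds is a 1.3-fold higher number from compound 2 to compound 3 (0.12 log units; within the scatter). Compound 4 `O=C(CCCc1cccc(Cl)c1)Nc1nc2ccccc2c(=O)s1` differs from compound 3 by 3-chlorobenzyl in place of 3-methoxyphenyl on a saturated chain carbon, two bonds along the chain from a carbonyl carbon. Within the data shown here, no measured step isolates chlorine against the methoxy group, and the lengthened chain of compound 4 is not covered by a single-point step either; what the values show is that compound 1, which also carries the longer chain, sits far below compound 3 in this assay, while the methoxy-for-hydrogen step stayed within the scatter. Compound 4 is therefore expected to land well below compound 3, by roughly a 5.5-fold lower number from compound 3 to compound 4 (0.74 log units; beyond the scatter). The estimate for compound 4 in this assay is 250 nM, with a range from 80 nM to 800 nM.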

Compound 4, inhibition constant: > 10000 nM
Compound 4 ended at the assay's limit; the forecaster's own chance of this, stated with the estimate: 5%; middle value at least 40-fold (1.60 log units) away from the limit.
By their numbers in this assay, from the lowest: compound 1; then compounds 2 and 3 (each within the scatter of the next). At a limit, above all of these: compound 4.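

Compound 4 gives no number in this assay, only a limit: the limit of > 10000 nM in this assay, at which 1 of the 4 values shown sits. With the chain of compound 1 kept, chloro in place of methoxy on an aromatic carbon gives an at least 46-fold higher number from compound 1 to compound 4 (1.66 log units; beyond the scatter), so at this chain length the substituent on the aromatic ring separates a measured number from the limit. The 3-chlorobenzyl group, on a saturated chain carbon, two bonds along the chain from a carbonyl carbon, also gives an at least 7.2-fold higher number from compound 3 to compound 4 (0.86 log units; beyond the scatter) in place of 3-methoxyphenyl and an at least 9.5-fold higher number from compound 2 to compound 4 (0.97 log units; beyond the scatter) in place of phenyl, so the longer chain by itself does not bring the lower number of compound 1.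

From the compounds shown here alone, what an unsubstituted phenyl, fluoro or hydroxy would give on the longer chain stays open. Going by these compounds, it therefore remains unknown whether methoxy favours the lower number or chloro opposes it, and an amine or a still longer chain is equally open.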